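The source may report more compounds than this note shows. Statements on the series, on what has been measured and on what is new or still open speak of the compounds shown alone.

Compound 1, `c1ccc2c(c1)CC(CCCN1CCN(c3cccc4c3OCCO4)CC1)C2`, gives 40 mg/kg in a functional assay on the whole organism for agonist activity, with Rattus norvegicus as the target; a higher number here means that more compound is needed for the effect, a lower number that less compound is needed.
Compound 2, `c1ccc2c(c1)CC2CCN1CCN(c2cccc3c2OCCCO3)CC1`, gives 40 mg/kg in this assay.
Compound 3, `COc1cc2c(cc1OC)C(CCN1CCN(c3cccc4c3OCCO4)CC1)CC2`, reaches only a limit of > 40 mg/kg in this assay, not a number; this is the limit of > 40 mg/kg in this assay, at which 1 of the 3 values shown sits.

Compound 2 stands level with compound 1 at the digits shown, so nothing separates them beyond the scatter. Among the compounds with values here, no two measured compounds differ in just one place, so no measured step guides what a single change does. Compound 4, `c1ccc2c(c1)CC2CN1CCN(c2cccc3c2OCCCO3)CC1`, differs from compound 2 in one place: a group of 8 heavy atoms (8 carbon; one four-membered non-aromatic ring of carbon only, one six-membered aromatic ring of carbon only) in place of a group of 9 heavy atoms (9 carbon; one four-membered non-aromatic ring of carbon only, one six-membered aromatic ring of carbon only), on a saturated chain carbon bound to an amine nitrogen in a ring. With only this to go on, a small step is expected in this assay, in no firm direction and not beyond the scatter. Compound 4 is therefore expected to give about 40 mg/kg, between 20 mg/kg and 80 mg/kg, a change of no change at the digits printed from compound 2 to compound 4 (within the scatter).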

Compound 4, minimum effective dose: > 10 mg/kg
Compound 4 gave a limit, no number; the forecaster's own chance of this, stated with the estimate: 35%; the middle value does not contradict the limit.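

The change from compound 2 to compound 4 cannot be read, because compound 4 gave only a limit, not a number: the limit of > 10 mg/kg in this assay, at which 1 of the 4 values shown sits.

From the compounds shown here alone, whether the group of 8 heavy atoms in compound 4 needs more or less compound than the group of 9 heavy atoms in compound 2 in this assay stays open.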